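Trifluoromethyl in place of fluoro on the ethoxy compound

The compounds below may be only part of what the source reports. "The series", "measured", "known", "first", "only" and "open" are said of these compounds alone.

In a functional assay on HeLa cells (Homo sapiens) for antiproliferative activity, read by CCK-8 assay, with a stated time of 72 h (on this read-out lower numbers stand for stronger inhibition and higher numbers for weaker inhibition), compound 1 `COc1ccc(-c2cncnc2-c2cc(OC)c(OC)c(OC)c2)cc1F` gives 500 nM as its value. Compound 2 `COc1ccc(-c2cncnc2-c2cc(OC)c(OC)c(OC)c2)cc1Cl` gives 320 nM on the same read-out and compound 3 `CCOc1ccc(-c2cncnc2-c2cc(OC)c(OC)c(OC)c2)cc1F` gives 470 nM on it as well. Compound 3 lies within the scatter of both other compounds, so these three values do not separate.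

Compound 4 `CCOc1ccc(-c2cncnc2-c2cc(OC)c(OC)c(OC)c2)cc1C(F)(F)F` differs from compound 3 by trifluoromethyl in place of fluoro on an aromatic carbon and thus has trifluoromethyl in place of fluoro on an aromatic carbon, ortho to an ethoxy group. Among the measured compounds shown here, two measured steps bear on this. Chloro in place of fluoro on an aromatic carbon gave a 1.6-fold lower number from compound 1 to compound 2 (0.19 log units; within the scatter) and is the nearer precedent. Methyl in place of hydrogen on the chain gave a 1.1-fold lower number from compound 1 to compound 3 (0.03 log units; within the scatter) and speaks only for the ethoxy group, which compound 4 keeps. Both steps stay within the scatter. Neither of them tests trifluoromethyl itself, so the data offer no firm direction. No step beyond the scatter is expected in this assay for this change. The estimated size is a 1.1-fold higher number from compound 3 to compound 4 (0.04 log units; within the scatter) and its direction remains uncertain. For compound 4 the estimate is 520 nM with an expected range from 180 nM to 1500 nM as the working figures.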

Compound 4, half-maximal inhibitory concentration: 790 nM
For compound 4 the middle estimate is 1.5-fold (0.18 log units) below the measured one, and the stated range covers the measured number.
By their numbers in this assay, from the lowest: compounds 2, 3, 1 and 4 (each within the scatter of the next, the first and the last beyond it).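

In this assay, trifluoromethyl in place of fluoro on the aromatic carbon ortho to an ethoxy group gives a 1.7-fold higher number from compound 3 to compound 4 (0.23 log units; within the scatter), so this exchange does not separate compound 4 from compound 3. The earlier steps shown here at this place tested only chloro in place of fluoro, on the methoxy compounds, whereas this change puts 4 heavy atoms where 1 heavy atom stood, and with the ethoxy group present, and the value still stays within the scatter of the fluoro compound. The series therefore shows that a larger group with no hydrogen-bond donors or acceptors can sit at this place without a step beyond the scatter, and no measurement at hand says what lies behind the size or direction of this step.

Still open, going by these compounds, is whether any group at this place can move the value beyond the scatter, for example an amine, a carboxylic acid or a nitrile in place of the trifluoromethyl of compound 4. Equally open, on these data alone, is whether a longer chain in place of the ethoxy group would keep the value of compound 4 within the scatter.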